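A few compounds are considered here, and "the series" means these few. Any claim that something is new, unique, unknown or untested is made for them only; others in the source may bear on it.

Measured compounds:
compound 1, `Cc1nc(C(c2ccc(-c3ccc4cccc(F)c4c3)[nH]c2=O)C(C)C)[nH]c1C`, gives 7 nM in an assay on CHO cells for displacement of a labelled ligand from prostaglandin E2 receptor EP3 subtype (Homo sapiens), read by radioligand binding; on this read-out lower numbers stand for stronger inhibition and higher numbers for weaker inhibition;
compound 2, `CC(C)C(/C=C1/CCNC1=O)c1ccc(-c2ccc3cccc(F)c3c2)[nH]c1=O`, gives 5.3 nM in this assay.

On the numbers shown, compound 2 sits at the low end, but only nominally, since the step of a 1.3-fold lower number from compound 1 to compound 2 (0.12 log units; within the scatter) lies within the scatter, so the two compounds are not told apart by this assay.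

Compound 3, `CC(C)C(CC(N)=O)c1ccc(-c2ccc3cccc(F)c3c2)[nH]c1=O`, differs from compound 2 in a single place: a group of 4 heavy atoms (2 carbon, 1 nitrogen, 1 oxygen; no ring) in place of a group of 7 heavy atoms (5 carbon, 1 nitrogen, 1 oxygen; one five-membered non-aromatic ring with 1 hetero atom), on a saturated chain carbon bound to an aromatic carbon and a saturated chain carbon. Among the compounds with values here, only one measured step bears on this position, the one from compound 1 to compound 2, where one ring group of the same size gave way to another, and that step was a 1.3-fold lower number from compound 1 to compound 2 (0.12 log units; within the scatter). Within the data shown here, it shows that the site accepts a swap of one ring for another without a change beyond the scatter, but no measured step opens the ring into a chain of fewer atoms, so the size of the present step is not anchored by the data. The account therefore expects a modest weakening, with a wide range either way. In this assay compound 3 is expected to give about 15 nM, between 4 nM and 60 nM. The step this estimate implies is expected to be a 2.8-fold higher number from compound 2 to compound 3 (0.45 log units; beyond the scatter).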

Compound 3, inhibition constant: 5 nM
Compound 3: the middle estimate sits 3.0-fold (0.48 log units) above what was measured; low and high end bracket the measured number.
By their numbers in this assay, from the lowest: compounds 3, 2 and 1 (each within the scatter of the next).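

In this assay, carbamoylmethyl takes the place of the five-membered non-aromatic ring group on the saturated chain carbon with a 1.1-fold lower number from compound 2 to compound 3 (0.03 log units; within the scatter), so a group with no ring holds this position as well as the ring group does, which the earlier swap of one ring group for another could not show. Set against the 4,5-dimethyl-1H-imidazol-2-yl group of the first compound, the same change gives a 1.4-fold lower number from compound 1 to compound 3 (0.15 log units; within the scatter), and the three groups, of 7, 7 and 4 heavy atoms, are therefore not told apart by this assay. Nothing shown here accounts for why such different groups read alike.

As far as these compounds go, it remains open how far this acceptance extends: a carboxylic acid, a primary amine, a plain alkyl chain or a longer chain ending in a carbamoyl group on the same saturated chain carbon would show whether the carbonyl or the amide hydrogens of carbamoylmethyl count at all. All three compounds also share the rest of the core, so whether the same equivalence holds when anything else in that core changes is likewise unsettled.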